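The source may report more compounds than this note shows. Statements on the series, on what has been measured and on what is new or still open speak of the compounds shown alone.

In a functional assay on SK-OV-3 cells (Homo sapiens) for inhibition, read by CCK-8 assay, with a stated time of 70 h (a higher number here means a weaker inhibitor, a lower number a stronger inhibitor), compound 1 `O=C(O)c1ccccc1COc1ccc(OCCOCCNC2CCCC2)cc1` reports only a limit, > 100000 nM. Compound 2 `COC(=O)c1ccc(COc2ccc(OCCOCCNC3CCCC3)cc2)cc1` gives 6990 nM, and compound 3 `Nc1cccc(COc2ccc(OCCOCCNC3CCCC3)cc2)c1` gives 10800 nM. Two measured steps lie beyond the scatter: an at least 14-fold lower number from compound 1 to compound 2 (1.15 log units; beyond the scatter) and an at least 9.2-fold lower number from compound 1 to compound 3 (0.96 log units; beyond the scatter). The third, a 1.5-fold higher number from compound 2 to compound 3 (0.19 log units; within the scatter), stays within it, so compound 3 stands level with compound 2. Compound 4 `COC(=O)c1cccc(COc2ccc(OCCOCCNC3CCCC3)cc2)c1` carries methoxycarbonyl in place of amino on an aromatic carbon, meta to a large group (methoxycarbonyl in place of amino on an aromatic carbon). The closest guide is compound 2, which already bears 4-(methoxycarbonyl)phenyl and gives 6990 nM, so no step beyond the scatter is expected in this assay. The expected change is small: a 1.4-fold lower number from compound 3 to compound 4 (0.13 log units; within the scatter). Compound 4 is estimated at 8000 nM, within an expected range of 3500 nM to 18000 nM.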

Compound 4, half-maximal inhibitory concentration: 45500 nM
Beside the measured number, compound 4's estimate is 5.7-fold (0.75 log units) below it; measured number above the stated range.
By their numbers in this assay, from the lowest: compounds 2 and 3 (each within the scatter of the next); then compound 4. At a limit, above all of these: compound 1.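

In this assay, for the compounds shown here, this position separates amino from methoxycarbonyl, with a 4.2-fold higher number from compound 3 to compound 4 (0.62 log units; beyond the scatter), a difference that the level standing of the earlier compounds 2 and 3 did not reveal. Where the methoxycarbonyl group sits also matters, since 3-(methoxycarbonyl)phenyl in place of 4-(methoxycarbonyl)phenyl gives a 6.5-fold higher number from compound 2 to compound 4 (0.81 log units; beyond the scatter). The comparison with compound 1 gives an at least 2.1-fold lower number from compound 1 to compound 4 (0.34 log units; beyond the scatter), but it can only be read against a limit: the limit of > 100000 nM in this assay, at which 1 of the 4 values shown sits.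

The compounds shown leave open how an amide or a hydroxyl group would read at this aromatic carbon. They also leave open whether the 3-(methoxycarbonyl)phenyl result would hold with a longer chain.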